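Adding a Third Methoxy Group to the Phenyl Ring

The source may hold more compounds than are shown below. What is called first, only, known or untested is meant among the compounds shown, and "the series" means these compounds.

Compound 1 `COc1ccc2nc(NC(=O)c3cc(-c4cc(OC)c(OC)c(OC)c4)n4nc(-c5ccccc5)cc4n3)sc2c1`: 5240 nM
Compound 2 `COc1ccc(-c2cc(C(=O)Nc3nc4cc(C)c(C)cc4s3)nc3cc(-c4ccccc4)nn23)cc1OC`: 8700 nM

Both numbers come from a functional assay on ACHN cells (Homo sapiens) for cytotoxicity, read by MTT assay, with a stated time of 48 h; on this read-out higher numbers stand for weaker inhibition and lower numbers for stronger inhibition. Compound 2 stands at the top of the two numbers shown, yet its gap to compound 1 lies within the scatter, so the two cannot be told apart on this evidence. Compound 3 `COc1cc(-c2cc(C(=O)Nc3nc4cc(C)c(C)cc4s3)nc3cc(-c4ccccc4)nn23)cc(OC)c1OC` differs from compound 2 in a single place: methoxy in place of hydrogen on an aromatic carbon. Compound 1 already carries the same 3,4,5-trimethoxyphenyl group, but it also bears a different substituent on the other side of the amide, so no clean reading of this change alone exists among the measured compounds. Only compound 1, with 5240 nM, hints at how the enlarged group behaves. The step is expected to be a 1.6-fold lower number from compound 2 to compound 3 (0.20 log units; within the scatter), leaning towards a lower number but not clearly beyond the scatter. Compound 3 is therefore estimated at 5500 nM, within 2000 nM to 15000 nM.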

Compound 3, half-maximal inhibitory concentration: 3800 nM
For compound 3 the middle estimate is 1.4-fold (0.16 log units) above the measured one, within the range that was stated.
By their numbers in this assay, from the lowest: compounds 3, 1 and 2 (each within the scatter of the next, the first and the last beyond it).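

In this assay, the third methoxy group gives a step that clears the scatter, a 2.3-fold lower number from compound 2 to compound 3 (0.36 log units; beyond the scatter), so going from 3,4-dimethoxyphenyl to 3,4,5-trimethoxyphenyl does register at this position, though only modestly. The other side of the amide now has a clean reading as well: with the 3,4,5-trimethoxyphenyl group held fixed, 5,6-dimethyl-1,3-benzothiazol-2-yl in place of 6-methoxy-1,3-benzothiazol-2-yl gives a 1.4-fold lower number from compound 1 to compound 3 (0.14 log units; within the scatter), which lies within the scatter, so these two groups cannot be told apart here. Nothing at hand explains why the added methoxy group lowers the number. From the compounds shown here alone, it remains open whether methoxy itself matters at this place, or whether a hydroxy group, a fluorine atom or an ethoxy group would give a similar step. The compounds shown also leave open whether this step would appear with the 6-methoxy-1,3-benzothiazol-2-yl group on the amide.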